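A few compounds are considered here, and "the series" means these few. Any claim that something is new, unique, unknown or untested is made for them only; others in the source may bear on it.

Among the compounds with values here, in a functional assay on A549 cells (Homo sapiens) for inhibition, read by CCK-8 assay, with a stated time of 48 h (on this read-out lower numbers stand for stronger inhibition and higher numbers for weaker inhibition), three compounds on a shared core have numbers so far. Compound 1 `COc1cc(-c2ccnc3cc(-c4ccc(Cl)cc4)nn23)cc(OC)c1OC` gives 3070 nM and compound 2 `COc1cc(-c2ccnc3cc(-c4ccc(C(F)(F)F)cc4)nn23)cc(OC)c1OC` gives 2070 nM while compound 3 `COc1ccc(-c2cc3nccc(-c4cc(OC)c(OC)c(OC)c4)n3n2)cc1` gives 376 nM as the lowest number of the three, making it the strongest inhibitor of this set. Trifluoromethyl in place of chloro gives a 1.5-fold lower number from compound 1 to compound 2 (0.17 log units; within the scatter) as one step. Methoxy gives an 8.2-fold lower number from compound 1 to compound 3 (0.91 log units; beyond the scatter) when it replaces chloro and a 5.5-fold lower number from compound 2 to compound 3 (0.74 log units; beyond the scatter) when it replaces trifluoromethyl on the same carbon.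

Compound 4 `COc1ccc(-c2cc3nccc(-c4cc(OC)c(OC)c(OC)c4)n3n2)cc1[N+](=O)[O-]` keeps that methoxy and gains a group: nitro in place of hydrogen on an aromatic carbon as nitro in place of hydrogen on an aromatic carbon, ortho to a methoxy group. Within the data shown here, no measured step adds a nitro, so the direction remains uncertain. Both measured moves away from methoxy, seen in reverse in an 8.2-fold lower number from compound 1 to compound 3 (0.91 log units; beyond the scatter) and a 5.5-fold lower number from compound 2 to compound 3 (0.74 log units; beyond the scatter) for scale, point to a small or modest rise as the likeliest outcome. For compound 4 the estimated value is 700 nM with an expected range from 180 nM to 2500 nM in this assay. This estimate means an expected 1.9-fold higher number from compound 3 to compound 4 (0.27 log units; within the scatter) overall.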

Compound 4, half-maximal inhibitory concentration: > 10000 nM
Compound 4 gave a limit, no number; the forecaster's own chance of this, stated with the estimate: 3%; at least 14-fold (1.15 log units) between middle value and limit.
By their numbers in this assay, from the lowest: compound 3; then compounds 2 and 1 (each within the scatter of the next). At a limit, above all of these: compound 4.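

Compound 3 and the compounds before it differ only in the group at one ring carbon, so they say nothing about the carbon ortho to a methoxy group. Within the data shown here, compound 4 fills that gap: in this assay, adding nitro at this carbon while keeping the methoxy gives an at least 26-fold higher number from compound 3 to compound 4 (1.42 log units; beyond the scatter), a larger step than any among the earlier compounds and one towards much weaker inhibition, so this position does not accept every added group. The result for compound 4 is a limit, not a number, so the true size of the step is unknown: the limit of > 10000 nM in this assay, at which 1 of the 4 values shown sits.

From the compounds shown here alone, whether the loss belongs to nitro itself or would follow any group added at this carbon remains open. Fluoro or an amine at the same carbon would help separate those two readings.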